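This account rests on a few compounds, and the source may have more. Where it says the series, first, only, none or still open, it means among the compounds named here.

Measured in a functional assay on MDA-MB-231 cells (Homo sapiens) for inhibition, read by CCK-8 assay, with a stated time of 48 h; a higher number here means a weaker inhibitor of growth, a lower number a stronger inhibitor of growth:
- compound 1 `CN1CCN(c2ccc(Nc3ncc(Cl)c(NCc4ccc(C(F)(F)F)cc4)n3)nc2)CC1`: 19100 nM
- compound 2 `Cc1ccc(CNc2nc(Nc3ccc(N4CCN(C)CC4)cn3)ncc2Cl)cc1`: 18600 nM
- compound 3 `Cc1ccc(Nc2nc(Nc3ccc(N4CCN(C)CC4)cn3)ncc2Cl)cc1`: 4030 nM

Compound 3 has the lowest number of the three in this assay, and its gaps to both others lie beyond the scatter. The next compound to be measured is compound 4 `CC(C)c1cccc(Nc2nc(Nc3ccc(N4CCN(C)CC4)cn3)ncc2Cl)c1`. The change is 3-isopropylphenyl in place of 4-methylphenyl on a nitrogen on an aromatic ring.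

Going by the values given here, two measured steps concern the group on this nitrogen, a 4.6-fold lower number from compound 2 to compound 3 (0.66 log units; beyond the scatter) and a 4.7-fold lower number from compound 1 to compound 3 (0.68 log units; beyond the scatter). Both are modest, but each replaces a benzyl group with 4-methylphenyl, and no benzyl group is involved in the new change. The closest parallel is a swap of one small group for another, a 1.0-fold lower number from compound 1 to compound 2 (0.01 log units; within the scatter), which stays within the scatter. Among the compounds with values here, no measured compound carries 3-isopropylphenyl, so the data give no direction for this exchange. A step within the scatter is therefore expected, though with a wide margin.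

For compound 4, the estimated value is 4000 nM, with an expected range from 1500 nM to 11000 nM. This estimate corresponds to a 1.0-fold lower number from compound 3 to compound 4 (0.00 log units; within the scatter).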

Compound 4, concentration for 50% growth inhibition: 5590 nM
For compound 4 the middle estimate is 1.4-fold (0.15 log units) below the measured one, within the range that was stated.
By their numbers in this assay, from the lowest: compounds 3 and 4 (each within the scatter of the next); then compounds 2 and 1 (each within the scatter of the next).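

In this assay the change from (4-methylphenyl)amino to (3-isopropylphenyl)amino gives a 1.4-fold higher number from compound 3 to compound 4 (0.14 log units; within the scatter) and so shows that, among the two phenyl groups tested on this nitrogen, the larger 3-isopropylphenyl group and the smaller 4-methylphenyl group cannot be told apart. Going by these compounds alone, the lower numbers relative to the benzyl compounds, earlier seen only with 4-methylphenyl, now also appear with a second phenyl group, as a 3.3-fold lower number from compound 2 to compound 4 (0.52 log units; beyond the scatter) and a 3.4-fold lower number from compound 1 to compound 4 (0.53 log units; beyond the scatter) show, both modest. Nothing among the available data bears on what lies behind the size of these steps.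

The compounds shown leave open whether the identity of the alkyl group or its place on the phenyl ring matters at this position, a question that 3-methylphenyl and 4-isopropylphenyl would address directly. They also leave open how a phenyl group carrying an amine or a carboxylic acid would behave on this nitrogen, and whether a longer chain than the benzyl link would keep the higher numbers of the benzyl compounds.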